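A few compounds are considered here, and "the series" means these few. Any claim that something is new, unique, unknown or untested is made for them only; others in the source may bear on it.

Working notes on the series. Compound 1 `NC(=O)c1c(NC(=O)c2ccccc2Cl)sc2c1CCN(Cc1cc(Cl)cc(Cl)c1)C2` is the reference point for the step considered here. In a functional assay on HeLa cells (Homo sapiens) for antiproliferative activity, with a stated time of 24 h (a lower number here means a stronger inhibitor, a higher number a weaker inhibitor), compound 1 gives 19600 nM, which is the only numerical result within the set. The two remaining results are limits of the assay rather than numbers. Compound 2 `NC(=O)c1c(NC(=O)c2ccc(C(F)(F)F)cc2)sc2c1CCN(Cc1c(Cl)cccc1Cl)C2` reaches only the limit > 50000 nM in this assay. Compound 3 `NC(=O)c1c(NC(=O)c2ccc(C(F)(F)F)cc2)sc2c1CCN(Cc1ccc(Cl)cc1Cl)C2` likewise reaches only the limit > 50000 nM in this assay. Within the data shown here, the one single-point step that can be traced among the measured compounds, a step that the two limits leave unreadable from compound 2 to compound 3, is therefore unreadable in size and direction, since the limit of > 50000 nM in this assay, at which 2 of the 3 values shown sit, holds both of its ends.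

Compound 4 `NC(=O)c1c(NC(=O)c2ccccc2Cl)sc2c1CCN(C(=S)Nc1c(Cl)cccc1Cl)C2` differs from compound 1 by a group of 11 heavy atoms (7 carbon, 1 nitrogen, 1 sulfur, 2 chlorine; one six-membered aromatic ring of carbon only) in place of a group of 9 heavy atoms (7 carbon, 2 chlorine; one six-membered aromatic ring of carbon only), on an amine nitrogen in a ring. Among the measured compounds shown here, no measured step touches this kind of exchange, and the one step recorded is itself unreadable, so there is nothing in the measured data that points to a direction for the change. The step from compound 1 to compound 4 is therefore expected to stay within the usual scatter, a 1.0-fold higher number from compound 1 to compound 4 (0.01 log units; within the scatter), with a wide uncertainty. Compound 4 is accordingly estimated at 20000 nM in this assay, within a range from 5000 nM to 80000 nM, with a real chance that only a limit is reported.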

Compound 4, half-maximal inhibitory concentration: 26500 nM
Beside the measured number, compound 4's estimate is 1.3-fold (0.12 log units) below it, within the range that was stated.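

Among these compounds, the first readable step lies on an amine nitrogen in a ring: in this assay there is a 1.4-fold higher number from compound 1 to compound 4 (0.13 log units; within the scatter). At this position, the 3,5-dichlorobenzyl group and the larger group of compound 4, which carries a double bond outside aromatic rings, a hydrogen-bond donor and a hydrogen-bond acceptor, therefore give values within the scatter of each other. The only earlier step, from compound 2 to compound 3, cannot be read, so the numerical part of the series remains small: the limit of > 50000 nM in this assay, at which 2 of the 4 values shown sit.

On these data alone, both groups compared at this nitrogen carry a dichlorinated aromatic ring of carbon only, so it stays open whether an unsubstituted benzyl group, a longer alkyl chain or a carboxylic acid at the same place would move the number beyond the scatter. As far as these compounds go, compound 4 differs from compound 2 and from compound 3 in more than one place, so the part played by the trifluoromethyl-bearing group on the other side of the shared core also remains open.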